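Replacing the Trifluoroethyl Group on a Carbonyl Carbon

The compounds below may be only part of what the source reports. "The series", "measured", "known", "first", "only" and "open" are said of these compounds alone.

Of the compounds shown here, two with a shared core have numbers so far in a functional assay on A2780 cells (Homo sapiens) for antiproliferative activity, read by CellTiter-Glo, with a stated time of 4 days; a lower number here means a stronger inhibitor, a higher number a weaker inhibitor. There, compound 1 (`O=C(N[C@@H](CO)c1ccc(NC(=O)[C@H]2C[C@@H]2c2cccnc2)cc1)c1ccccc1`) gives 200 nM, and compound 2 (`C[C@H](NC(=O)CC(F)(F)F)c1ccc(NC(=O)[C@H]2C[C@@H]2c2cccnc2)cc1`) gives 5 nM. Compound 2 therefore holds the lower and better number of the two, and the gap lies beyond the usual scatter of repeated measurements. These two compounds differ in more than one place, so their gap cannot be pinned on any single change.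

Compound 3 (`C[C@H](NC(=O)[C@@H]1CCCN1C)c1ccc(NC(=O)[C@H]2C[C@@H]2c2cccnc2)cc1`) has not been measured yet. It has 1-methylpyrrolidin-2-yl in place of 2,2,2-trifluoroethyl on a carbonyl carbon, (1-methylpyrrolidin-2-yl in place of 2,2,2-trifluoroethyl on a carbonyl carbon). Within the data shown here, no measured pair isolates this exchange, so any forecast is loose. Compound 2 at 5 nM already sits low, while compound 1, with another group on that carbonyl, sits at 200 nM, which makes a weaker result the likelier direction in this assay. The expected change is a moderate loss of potency, a 4.0-fold higher number from compound 2 to compound 3 (0.60 log units; beyond the scatter), probably beyond the scatter. For compound 3 the estimated value is 20 nM, with an expected range from 4 nM to 100 nM.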

Compound 3, half-maximal inhibitory concentration: 1 nM
Estimate against measurement, compound 3: 20-fold (1.30 log units) above; measured number outside the range, below it.
By their numbers in this assay, from the lowest: compound 3; then compound 2; then compound 1.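

In this assay, putting 1-methylpyrrolidin-2-yl in place of 2,2,2-trifluoroethyl on a carbonyl carbon gives a 5.0-fold lower number from compound 2 to compound 3 (0.70 log units; beyond the scatter) and is the only single-place change shown here. It shows that the low number of compound 2 was not the limit for this position, and that the position accepts a larger group carrying a five-membered ring, a ring nitrogen and a defined stereocentre, with a further gain in potency. Because all of these features enter together, this one step cannot show which of them matters, and nothing measured here accounts for the gain.

The compounds shown leave open whether the ring itself, its nitrogen or the methyl on that nitrogen is what counts, which an open-chain dimethylaminomethyl group or an unmethylated pyrrolidin-2-yl group would help to separate. They also leave open how much the defined stereocentre contributes, a question that the mirror-image 1-methylpyrrolidin-2-yl group on the same carbonyl carbon would address.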